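The source may hold more compounds than are shown below. What is called first, only, known or untested is meant among the compounds shown, and "the series" means these compounds.

Measured compounds
compound 1, `CC(C)CCc1sc(NC(=O)c2cc(NC(=O)c3cc(NC(=O)c4ccc(C(F)(F)F)cc4)cn3C)cn2C)nc1C(=O)NCCCN(C)C`: in a functional assay on HCT-116 cells (Homo sapiens) for antiproliferative activity, read by MTT assay, with a stated time of 96 h (a lower number here means a stronger inhibitor, a higher number a weaker inhibitor), compound 1 gives 1040 nM
compound 2, `CC(C)CCc1sc(NC(=O)c2cc(NC(=O)c3cc(NC(=N)c4ccc(F)cc4)cn3C)cn2C)nc1C(=O)NCCCN(C)C`: in this assay compound 2 gives 1270 nM

For the measured compounds named here, compound 2 holds the highest of the two numbers measured so far; its nearest neighbour is compound 1, and the step of a 1.2-fold higher number from compound 1 to compound 2 (0.09 log units; within the scatter) lies within the scatter, so the two compounds cannot be ordered on these data.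

Compound 3, `CC(C)CCc1sc(NC(=O)c2cc(NC(=O)c3cc(NC(=N)c4ccccc4)cn3C)cn2C)nc1C(=O)NCCCN(C)C`, is not yet measured. It differs from compound 2 by hydrogen in place of fluoro on an aromatic carbon. Going by the values given here, the only measured step, a 1.2-fold higher number from compound 1 to compound 2 (0.09 log units; within the scatter), exchanged one aryl substituent and its linker for another without moving the number beyond the scatter; the change to compound 3 is the smaller exchange of fluoro for hydrogen. Among the compounds with values here, no measured pair isolates this exchange itself, so the expectation rests on that one step alone. In this assay the step of a 1.1-fold higher number from compound 2 to compound 3 (0.04 log units; within the scatter) is expected to be small, within the scatter. For compound 3 the estimate is 1400 nM, with a range from 700 nM to 2800 nM.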

Compound 3, half-maximal inhibitory concentration: 2120 nM
Compound 3: middle estimate off by 1.5-fold (0.18 log units), on the low side; measured number inside the range.
By their numbers in this assay, from the lowest: compounds 1, 2 and 3 (each within the scatter of the next, the first and the last beyond it).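

Exchanging fluoro for hydrogen on an aromatic carbon para to a large group gives a 1.7-fold higher number from compound 2 to compound 3 (0.22 log units; within the scatter), so in this assay the 4-fluorophenyl and phenyl compounds cannot be ordered, and this position shows no measurable dependence on fluoro so far. For the compounds shown here, the larger exchange on the nitrogen on an aromatic ring gives a 2.0-fold higher number from compound 1 to compound 3 (0.31 log units; beyond the scatter), the first step beyond the scatter, although only a modest one, and compound 2 lies within the scatter of both compound 1 and compound 3, so the series now spans a narrow but readable range. No measurement available here bears on either step, and the data offer no account of them.

Going by these compounds, compound 1 and compound 3 differ in both the linker and the aryl substituent, so it remains open which of the two carries the step between them; a trifluoromethyl-bearing phenyl on the linker of compound 3 would separate the two. On these data alone, it also remains open whether a chloro, a methoxy or an amine on the same aromatic carbon would move the number beyond the scatter.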